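The compounds below may be only part of what the source reports. "The series", "measured", "known", "first", "only" and "open" are said of these compounds alone.

Three analogues built on one shared core have been tested in a functional assay for antagonist activity at transient receptor potential cation channel subfamily V member 1 (Homo sapiens), read by FLIPR; a higher number here means a weaker inhibitor, a lower number a stronger inhibitor. Compound 1 `Cc1cccnc1-c1ccc(C(=O)Nc2ccc(C(C)C)cc2)cc1` gives 73 nM. Compound 2 `Cc1cccnc1-c1ccc(C(=O)Nc2ccc(F)cc2)cc1` reaches only > 4000 nM, which is a limit of the assay rather than a number (the limit of > 4000 nM in this assay, at which 1 of the 3 values shown sits). Compound 3 `Cc1cccnc1-c1ccc(C(=O)Nc2ccc(Cl)cc2)cc1` gives 1500 nM, the highest of the two numbers in this assay; its nearest neighbour is compound 1, separated by the large step of a 21-fold higher number from compound 1 to compound 3 (1.31 log units; beyond the scatter), chloro in place of isopropyl. Between compound 2 and compound 3 the step of an at least 2.6-fold lower number from compound 2 to compound 3 (0.42 log units; beyond the scatter), chloro in place of fluoro, is at least modest.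

Compound 4 `Cc1cccnc1-c1ccc(C(=O)Nc2ccc(C(F)(F)F)cc2)cc1` has not yet been measured. Its change from compound 3 is trifluoromethyl in place of chloro on an aromatic carbon, on an aromatic carbon of a six-membered aromatic ring of carbon only, para to a large group. Both measured steps touch this same substituent: the at least modest step an at least 2.6-fold lower number from compound 2 to compound 3 (0.42 log units; beyond the scatter) and the large step of a 21-fold higher number from compound 1 to compound 3 (1.31 log units; beyond the scatter). Trifluoromethyl, with its four heavy atoms, sits between chloro and isopropyl in this row, so a modest step toward a lower number is expected, namely a 3.0-fold lower number from compound 3 to compound 4 (0.48 log units; beyond the scatter). For compound 4 the estimated value in this assay is 500 nM, with a range from 150 nM to 1800 nM.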

Compound 4, half-maximal inhibitory concentration: 65 nM
Compound 4: the middle estimate sits 7.7-fold (0.89 log units) above what was measured; the measured number lies below the stated range.
By their numbers in this assay, from the lowest: compounds 4 and 1 (each within the scatter of the next); then compound 3. At a limit, above all of these: compound 2.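

In this assay, the change at this aromatic carbon is far from gradual: the step of a 23-fold lower number from compound 3 to compound 4 (1.36 log units; beyond the scatter) shows that trifluoromethyl in place of chloro is a large change, not a partial move toward the isopropyl compound. Trifluoromethyl and isopropyl cannot be told apart here, since the step of a 1.1-fold lower number from compound 1 to compound 4 (0.05 log units; within the scatter) stays within the scatter, so the four compounds now fall into a group of two with low numbers, compound 1 and compound 4, and the halogen compounds, compound 2 and compound 3, which stand well apart from them. The step of an at least 61-fold lower number from compound 2 to compound 4 (1.78 log units; beyond the scatter) rests on a limit of the assay and not on a number: the limit of > 4000 nM in this assay, at which 1 of the 4 values shown sits.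

The compounds shown leave open how a tert-butyl group, a methoxy group, a nitrile or a carboxylic acid on the same aromatic carbon would read, and whether any group there would take the number lower than the pair already in hand. From the compounds shown here alone, only this one substituent varies across the shared core, so it also remains open whether trifluoromethyl would keep this large effect if another part of the core were changed.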